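Fluoro to methyl exchange carried over to a second core

The source may report more compounds than this note shows. Statements on the series, on what has been measured and on what is new or still open speak of the compounds shown alone.

Measured compounds:
compound 1 `Fc1ccc(-c2csc(N/N=C/c3ccc(Cl)cc3Cl)n2)cc1` gives 90.7%
compound 2 `Cc1ccc(-c2csc(N/N=C/c3ccc(Cl)cc3Cl)n2)cc1` gives 86%
compound 3 `Fc1ccc(-c2csc(N/N=C/c3cccs3)n2)cc1` gives 92.4%

All three were tested in a functional assay, read by spectrophotometry, with a stated time of 15 min, tested at 20 ug/mL; on this read-out lower numbers stand for a weaker effect and higher numbers for a stronger effect at the one concentration tested. Within the first pair, compound 2 differs from compound 1 by methyl in place of fluoro on an aromatic carbon, and the step is a number 4.7 percentage points lower from compound 1 to compound 2 (within the scatter). On this read-out the two compounds therefore cannot be told apart.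

Compound 3 carries a different core; the difference between the core of compound 3 and the core of compound 1 is not broken down here. In this assay compound 3 gives a number that lies within the scatter of both compound 1 and compound 2, so no order among the three measured compounds can be drawn from these values.

Compound 4 `Cc1ccc(-c2csc(N/N=C/c3cccs3)n2)cc1` has not yet been measured. It differs from compound 3 by methyl in place of fluoro on an aromatic carbon. Among the measured compounds shown here, this is the same change, at the same place, as the one made from compound 1 to compound 2, which is the only time it has been measured.

For the measured compounds named here, the step of a number 4.4 percentage points lower from compound 3 to compound 4 (within the scatter) is expected to be small, resting on the single earlier step of a number 4.7 percentage points lower from compound 1 to compound 2 (within the scatter), which stayed within the scatter. Compound 4 is accordingly estimated to give 88% in this assay, with the likely range running from 78% to 95%. This expectation rests on one prior example only.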

Compound 4, a percentage reported as inhibition, at one concentration (the size of the read-out at that concentration, not a potency): 90.9%
The estimate for compound 4 lay 2.9 percentage points below the measured number; low and high end bracket the measured number.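

In this assay, methyl in place of fluoro on an aromatic carbon of the six-membered ring, para to a large group, gives a number 1.5 percentage points lower from compound 3 to compound 4 (within the scatter). Set beside the earlier step, the change reads alike on the two cores shown, and neither step can be told from repeat measurement: the same change on two cores in this assay, a number 4.7 percentage points lower (within the scatter) from compound 1 to compound 2 and a number 1.5 percentage points lower (within the scatter) from compound 3 to compound 4, 3.2 percentage points apart, within the scatter of two such steps
This supports only a narrow working statement: on these two cores, in this assay and at its one concentration, the exchange of fluoro for methyl leaves no readable mark, but it does not show that the change is without effect in general, that it would stay as small on a further core, or that the two steps would remain alike at another concentration.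

The compounds shown leave open whether any other group at this place, such as an amine, a carboxylic acid or a longer chain, would shift the number beyond the scatter on either core. They also leave open how the effect of the four compounds would compare at any other concentration, as each compound has a reading at a single concentration only, and a single reading of that kind speaks only of a stronger or weaker effect at that concentration.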